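The source may hold more compounds than are shown below. What is called first, only, known or untested is meant among the compounds shown, and "the series" means these compounds.

Measured so far:
compound 1, `CNC(=O)/C=C/c1ccncc1-c1ccc2c(cnn2C)c1`, in a functional assay on A549 cells (Homo sapiens) for inhibition, read by sulforhodamine B assay, with a stated time of 72 h; a higher number here means a weaker inhibitor of growth, a lower number a stronger inhibitor of growth: > 10000 nM
compound 2, `CNC(=O)/C=C/c1ccncc1-c1ccc2c(ccn2C)c1`: 6450 nM
compound 3, `CCOC(=O)/C=C/c1ccncc1-c1ccc2cc[nH]c2c1`: 5740 nM

All three compounds share the acrylic carbonyl chain attached to a pyridine bearing a bicyclic aromatic group, and they differ in the group on the carbonyl carbon and in the bicyclic part. Compound 1 sits at the limit of > 10000 nM in this assay, at which 1 of the 3 values shown sits, and this is a limit of the assay rather than a measured number. Among the measured compounds shown here, compound 2 and compound 3 each differ from compound 1 in more than one place, so no single step connects either of them to compound 1; their values show only that both lie inside the measurable range and close to one another.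

Compound 4, `CCOC(=O)/C=C/c1ccncc1-c1ccc2c(cnn2C)c1`, is made from compound 1 by one change: ethoxy in place of methylamino on a carbonyl carbon. Because compound 1 is known only as a limit, the step cannot be counted from a measured number; it is expected to be small, with compound 4 at most modestly stronger as an inhibitor of growth, an expected step that the limit leaves unreadable from compound 1 to compound 4 that need not reach beyond the scatter. Compound 4 is therefore estimated at 12000 nM in this assay, with an expected range from 4000 nM to 40000 nM.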

Compound 4, concentration for 50% growth inhibition: 5030 nM
Compound 4: middle estimate off by 2.4-fold (0.38 log units), on the high side; measured number inside the range.
By their numbers in this assay, from the lowest: compounds 4, 3 and 2 (each within the scatter of the next). At a limit, above all of these: compound 1.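

In this assay, putting ethoxy in place of methylamino on a carbonyl carbon gives an at least 1.9-fold lower number from compound 1 to compound 4 (0.29 log units; that floor lies within the scatter). Among the compounds shown here, this is the only step so far between compounds that differ in one place, and it shows that this carbonyl position can tolerate the change from the amide to the ester, since compound 4 gives a measured number of 5030 nM inside the range of the assay. How large the step really is, and whether it truly goes beyond the scatter, stays unknown because compound 1 is held only at a limit and not at a number: the limit of > 10000 nM in this assay, at which 1 of the 4 values shown sits.

The compounds shown give no reading for a carboxylic acid on this carbonyl carbon, nor for an amine such as dimethylamino or a longer chain such as butoxy in the same place. For the compounds shown here, they also hold no pair that repeats the change from methylamino to ethoxy on another bicyclic part, so whether it would carry over to the core of compound 2 remains open.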